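A few compounds are considered here, and "the series" means these few. Any claim that something is new, unique, unknown or untested is made for them only; others in the source may bear on it.

Working notes on the oxazolidinone series, three compounds measured and one pending.

Compound 1 `CCN1CCN(C[C@H]2CN(c3ccc(-n4cc(-c5ccccn5)cn4)c(F)c3)C(=O)O2)CC1` gives 2.19 in a physicochemical assay for lipophilicity, read by HPLC, measured as octanol-water partition; on this read-out lower numbers stand for lower lipophilicity and higher numbers for higher lipophilicity. Compound 2 `O=C1O[C@@H](CN2CCCCC2)CN1c1ccc(-n2cc(-c3ccccn3)cn2)c(F)c1` gives 3.1 in this assay, and compound 3 `O=C(NC[C@H]1CN(c2ccc(-n3cc(-c4ccccn4)cn3)c(F)c2)C(=O)O1)C(F)F` gives 1.9 in this assay. Compound 3 holds the lowest of the three numbers; compound 1 sits nearest to it, within the scatter, and compound 2 sits furthest, beyond it. The measured steps are a number 0.91 log units higher from compound 1 to compound 2 (beyond the scatter), a number 0.29 log units lower from compound 1 to compound 3 (within the scatter) and a number 1.20 log units lower from compound 2 to compound 3 (beyond the scatter); each of them swaps the group on the saturated chain carbon bound to the ring.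

Compound 4 `CNC(=O)[C@H]1CN(c2ccc(-n3cc(-c4ccccn4)cn3)c(F)c2)C(=O)O1` differs from compound 3 in another way: methylcarbamoyl in place of (((difluoromethyl)carbonyl)amino)methyl on a saturated ring carbon. The chain itself is gone, and a smaller group sits directly on the ring carbon. None of the three measured steps covers a change of this kind, so they give no direct calibration. The leaving group carries two fluorines and seven heavy atoms, the entering group four heavy atoms with the same donor and acceptor count, which gives some ground to expect a modest lowering, though the step may also fall within the scatter.

For compound 4 the estimate in this assay is 1.5, with a range from 1 to 2.1. That estimate means an expected step of a number 0.40 log units lower from compound 3 to compound 4 (beyond the scatter).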

Compound 4, partition coefficient: 1.39
Beside the measured number, compound 4's estimate is 0.11 log units above it; measured number inside the range.
By their numbers in this assay, from the lowest: compound 4; then compounds 3 and 1 (each within the scatter of the next); then compound 2.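

The earlier steps shown here all swapped the group on the saturated chain carbon, whereas here the whole (((difluoromethyl)carbonyl)amino)methyl group on the saturated ring carbon gives way to methylcarbamoyl, and in this assay this gives a number 0.51 log units lower from compound 3 to compound 4 (beyond the scatter) even though the counted donors and acceptors stay the same. Compounds 1 and 3 could not be told apart in this assay, but methylcarbamoyl separates from both, with a number 0.80 log units lower from compound 1 to compound 4 (beyond the scatter) alongside the step above, and with a number 1.71 log units lower from compound 2 to compound 4 (beyond the scatter) as the widest gap in the set, so compound 4 holds the lowest number with every step to it beyond the scatter. Nothing available bears on the reason for these steps.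

The step from compound 3 to compound 4 changes several things at once, so the share of the lost fluorines, of the shorter attachment and of the turned amide cannot be split. An (acetylamino)methyl group would isolate the fluorines, and a (methylcarbamoyl)methyl group would keep the chain carbon while carrying the same amide as compound 4, so these two would divide the step.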